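A few compounds are considered here, and "the series" means these few. Any claim that something is new, unique, unknown or untested is made for them only; others in the source may bear on it.

Measured compounds:
- compound 1, `CCCCN(CC)c1nc(C)nc2c1nnn2-c1c(C)cc(C)nc1C`, with 65 nM 
- compound 2, `CCC(COC)Nc1nc(C)nc2c1nnn2-c1c(C)cc(C)cc1C`, with 59.4 nM 
- compound 3, `CCCCN(CC)c1nc(C)nc2c1nnn2-c1ccc(C(C)C)cc1Br`, with 7.5 nM 

These three share a core and were tested in an in vitro assay on 293-EBNA cells for binding affinity to corticotropin-releasing factor receptor 1 (Homo sapiens); a lower number here means a stronger inhibitor, a higher number a weaker inhibitor. Compound 3 shows the lowest number of the three, and its distance from compound 2 and from compound 1 lies beyond the usual scatter in each case, so compound 3 is the strongest binder among them. The three compounds differ in more than one place, so no single structural change can be read from their values alone.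

Compound 4, `CCCCNc1nc(C)nc2c1nnn2-c1ccc(C(C)C)cc1Br`, is a close relative of compound 3. For the measured compounds named here, the only change is hydrogen in place of ethyl on a nitrogen on an aromatic ring. Nothing measured here shows what such a change does on its own, since compound 2, which also carries a hydrogen on this nitrogen, differs from compound 3 in other places as well. For compound 4 in this assay a slight rise in the number is expected, and the expected step is a 2.0-fold higher number from compound 3 to compound 4 (0.30 log units; within the scatter), which may well stay within the scatter. Compound 4 is thus estimated at 15 nM, within a range from 5 nM to 45 nM.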

Compound 4, inhibition constant: 69.6 nM
Compound 4: middle estimate off by 4.6-fold (0.67 log units), on the low side; measured number above the stated range.
By their numbers in this assay, from the lowest: compound 3; then compounds 2, 1 and 4 (each within the scatter of the next).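

In this assay, for the compounds shown here, this is the first reading of this position on its own: a 9.3-fold higher number from compound 3 to compound 4 (0.97 log units; beyond the scatter), a step beyond the scatter, with hydrogen in place of ethyl on the nitrogen and nothing else changed. On this background, then, butylamino binds more weakly than butyl(ethyl)amino, so the ethyl on this nitrogen matters for the number and cannot be removed without cost. Nothing measured here explains why the number rises with this change.

On these data alone, this is a single pair on a single background, so it remains open whether the same change would give a similar step with the other aromatic groups seen in compound 1 and compound 2. The compounds shown also leave open how a methyl, a propyl or a longer chain in place of the ethyl on this nitrogen would compare.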